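Swapping the pyrazole substituents on compound 2

A few compounds are considered here, and "the series" means these few. Any claim that something is new, unique, unknown or untested is made for them only; others in the source may bear on it.

Of the compounds shown here, three sharing one core have been measured in an assay on isolated protein for inhibition of Leucine-rich repeat serine/threonine-protein kinase 2 variant G2019S (Homo sapiens), read by TR-FRET and LanthaScreen, with stated times of 50 min and 30 min, in the presence of a further agent that is not named here; a lower number here means a stronger inhibitor, a higher number a weaker inhibitor. Compound 1 `C[C@@H]1CCCN1c1[nH]c2ncnc(N)c2c1C#N` gives 201 nM. For the measured compounds named here, compound 3 `C[C@@H]1CCCN1c1c(C#N)c2c(N)ncnc2n1C` gives 11 nM, and the single step of an 18-fold lower number from compound 1 to compound 3 (1.26 log units; beyond the scatter) is the only change with a known outcome here. Compound 2 `C[C@@H]1CCCN1c1c(C#N)c2c(N)nc(Nc3cn(C)nc3C(F)(F)F)nc2n1C` gives 358 nM, the highest of the three numbers; it sits within the scatter of compound 1 and far from compound 3.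

Compound 4 `Cc1nn(C2COC2)cc1Nc1nc(N)c2c(C#N)c(N3CCC[C@H]3C)n(C)c2n1` differs from compound 2 in one place: 3-methyl-1-(oxetan-3-yl)-1H-pyrazol-4-yl in place of 1-methyl-3-(trifluoromethyl)-1H-pyrazol-4-yl on a nitrogen on an aromatic ring. Going by the values given here, no measured step concerns this pyrazole swap; the measured step covers only the methyl on the aromatic nitrogen, which compounds 2 and 4 share. With nothing to guide direction, the step of a 1.3-fold lower number from compound 2 to compound 4 (0.11 log units; within the scatter) is expected to stay within the scatter. Compound 4 is therefore estimated at 280 nM in this assay, with a range from 90 nM to 900 nM, anchored on the value of compound 2.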

Compound 4, half-maximal inhibitory concentration: 25 nM
For compound 4 the middle estimate is 11-fold (1.05 log units) above the measured one; the whole stated range lies above it.
By their numbers in this assay, from the lowest: compound 3; then compound 4; then compounds 1 and 2 (each within the scatter of the next).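

In this assay, the group on this nitrogen on an aromatic ring strongly affects the result: a 14-fold lower number from compound 2 to compound 4 (1.16 log units; beyond the scatter). This is a large step for a swap in which the leaving and entering groups both hold 10 heavy atoms and both keep a pyrazole, and it shows that changing the substituents on that pyrazole can matter as much as the methyl on the aromatic nitrogen did. No evidence here explains the step.

The swap replaces trifluoromethyl with methyl and, at the same time, methyl with oxetan-3-yl, so these compounds leave open which of the two changes accounts for the step. A 1,3-dimethyl-1H-pyrazol-4-yl group in the same place would help to separate the two.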